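The compounds below may be only part of what the source reports. "The series", "measured", "known", "first", "only" and "open" are said of these compounds alone.

Measured compounds:
- compound 1 `COC(=O)c1ccccc1OCc1cn(-c2ccc(S(=O)(=O)N3CCc4ccccc4C3)cc2)nn1`: 630 nM
- compound 2 `COc1cc2c(cc1OC)CN(S(=O)(=O)c1ccc(-n3cc(COc4ccccc4C)nn3)cc1)CC2`: 39700 nM
- compound 3 `COc1cc2c(cc1OC)CN(S(=O)(=O)c1ccc(-n3cc(COc4ccc(C=O)cc4OC)nn3)cc1)CC2`: 40000 nM

In a functional assay on HuCC-A1 cells (Homo sapiens) for cytotoxicity, read by MTT assay, with a stated time of 48 h (on this read-out lower numbers stand for stronger inhibition and higher numbers for weaker inhibition), compound 1 gives the lowest of the three numbers, far apart from the other two, which sit close together. Compound 4 `O=S(=O)(c1ccc(-n2cc(CO)nn2)cc1)N1CCc2ccccc2C1` is compound 1 stripped of its aryl ester: hydrogen in place of 2-(methoxycarbonyl)phenyl on an oxygen on a saturated carbon. For the measured compounds named here, no measured step covers this kind of change. Going by the values given here, the only measured step, a 1.0-fold higher number from compound 2 to compound 3 (0.00 log units; within the scatter), exchanges one substituted phenyl for another on a differently decorated core and leaves the number unchanged, so it says little about removing the whole group. The gap between compound 1 and compounds 2 and 3 cannot be split between the core and the aryl group from the data shown. Taking the aryl ester away removes a sizeable part of the molecule, so a marked weakening is expected: a 9.5-fold higher number from compound 1 to compound 4 (0.98 log units; beyond the scatter). Compound 4 is therefore estimated at 6000 nM, within a range of 1200 nM to 40000 nM, pending measurement.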

Compound 4, half-maximal inhibitory concentration: 51400 nM
Compound 4: the middle estimate sits 8.6-fold (0.93 log units) below what was measured; measured number above the stated range.
By their numbers in this assay, from the lowest: compound 1; then compounds 2, 3 and 4 (each within the scatter of the next).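

In this assay, replacing the 2-(methoxycarbonyl)phenyl on the oxygen with hydrogen gives an 82-fold higher number from compound 1 to compound 4 (1.91 log units; beyond the scatter) and leaves a hydroxymethyl in place of the (2-(methoxycarbonyl)phenoxy)methyl, so on the core of compound 1 the number depends heavily on having this group. The earlier step of a 1.0-fold higher number from compound 2 to compound 3 (0.00 log units; within the scatter) only exchanged one substituted phenyl for another on a different core, and it could not show that losing the whole group matters this much. Nothing measured here explains the size of the new step.

On these data alone, what stays open is which part of the group counts, the phenyl ring itself or its methyl ester. A plain phenyl, or a carboxylic acid in place of the ester, on this same core would begin to separate the two.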